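The source may hold more compounds than are shown below. What is called first, only, known or untested is meant among the compounds shown, and "the series" means these compounds.

Series notes. The shared core is held fixed; variation sits on the aryl ring attached to the sulfonyl sulfur. Compound 1 `Cc1ccc2ncc(S(=O)(=O)c3ccccc3)c(N3CCC(C)CC3)c2c1` carries the unsubstituted phenyl, and in an assay on isolated protein for displacement of a labelled ligand from metabotropic glutamate receptor 5 (Homo sapiens), with a stated time of 60 min, tested at 1 uM (on this read-out lower numbers stand for less inhibition and higher numbers for more inhibition at the one concentration tested (going by the name of the read-out)), compound 1 gives 67%. Compound 2 `Cc1ccc2ncc(S(=O)(=O)c3ccc(F)c(Cl)c3)c(N3CCC(C)CC3)c2c1`, with 3-chloro-4-fluorophenyl in place of phenyl on the sulfonyl sulfur, gives 93% in this assay, and compound 3 `Cc1ccc2ncc(S(=O)(=O)c3cccc(Cl)c3)c(N3CCC(C)CC3)c2c1`, with a single chloro, gives 91%. Compound 3 thus stands second highest of the three numbers: the step of a number 24 percentage points higher from compound 1 to compound 3 (beyond the scatter) is beyond the scatter, as is a number 26 percentage points higher from compound 1 to compound 2 (beyond the scatter), whereas a number 2 percentage points lower from compound 2 to compound 3 (within the scatter) lies within it.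

Compound 4 `Cc1ccc2ncc(S(=O)(=O)c3cccc(F)c3)c(N3CCC(C)CC3)c2c1` has not been measured. Its change from compound 3 is fluoro in place of chloro on an aromatic carbon. Among the measured compounds shown here, two measured steps bear on it. Putting chloro onto the bare ring, a number 24 percentage points higher from compound 1 to compound 3 (beyond the scatter), raised the read-out clearly; taking fluoro off compound 2, a number 2 percentage points lower from compound 2 to compound 3 (within the scatter), moved nothing beyond the scatter, though that fluoro sat on a different carbon and with chloro retained. For the measured compounds named here, no direct chloro-to-fluoro step exists in the set. Fluoro is expected to hold only part of what chloro gave, so a moderate fall is expected, a number 13 percentage points lower from compound 3 to compound 4 (beyond the scatter). Compound 4 is expected at 78%, with a range from 62% to 92%.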

Compound 4, a percentage reported as inhibition, at one concentration (the size of the read-out at that concentration, not a potency): 94%
Compound 4: middle estimate off by 16 percentage points, on the low side, outside the stated range (above it).
By their numbers in this assay, from the lowest: compound 1; then compounds 3, 2 and 4 (each within the scatter of the next).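

Replacing chloro with fluoro at this place, meta to a large group, gives up nothing on the read-out in this assay: a number 3 percentage points higher from compound 3 to compound 4 (within the scatter) and the fuller ring offers no separation either, with a number 1 percentage points higher from compound 2 to compound 4 (within the scatter) as the matching step. A lone fluoro on the bare phenyl is enough for the rise, as a number 27 percentage points higher from compound 1 to compound 4 (beyond the scatter) marks a move of about the size that chloro gave in the earlier step, so this rise does not need chloro at this place. A fluoro on the aryl ring therefore has no single weight across the series, and its loss matters only where no chloro remains or where it is the sole substituent, as two matched steps show: the same change on two cores in this assay, a number 2 percentage points lower (within the scatter) from compound 2 to compound 3 and a number 27 percentage points lower (beyond the scatter) from compound 4 to compound 1, 25 percentage points apart, beyond the scatter of two such steps.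

On these data alone, compounds 2, 3 and 4 sit together at the top of a read-out taken at one concentration, so it stays open how they would rank on a full potency measure. Also open, as far as these compounds go, is whether a methoxy, a nitrile or an amine on the same aromatic carbon would hold the read-out as the two halogens do.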